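A few compounds are considered here, and "the series" means these few. Any claim that something is new, unique, unknown or untested is made for them only; others in the source may bear on it.

In a functional assay on A549 cells (Homo sapiens) for inhibition, read by CCK-8 assay, with a stated time of 48 h (a lower number here means a stronger inhibitor, a higher number a weaker inhibitor), compound 1 `COc1cc(-c2ccnc3cc(-c4cccc(C#N)c4)nn23)cc(OC)c1OC` gives > 10000 nM, which is a limit of the assay and not a number. For the measured compounds named here, compound 2 `COc1cc(-c2ccnc3cc(-c4cccc(C)c4)nn23)cc(OC)c1OC` gives 5730 nM, the only true number so far, and it marks a weak inhibitor. Going by the values given here, the single measured step, an at least 1.7-fold lower number from compound 1 to compound 2 (0.24 log units; that floor lies within the scatter), changes only a small group on the phenyl ring, and its floor lies within the scatter. Compound 3 `COc1cc(-c2ccnc3cc(-c4ccc5cnn(C)c5c4)nn23)cc(OC)c1OC` makes a larger change at that place: 1-methyl-1H-indazol-6-yl in place of 3-methylphenyl on an aromatic carbon. That step offers little guide to a swap of the whole group, so the expectation is loose, leaning towards a lower number. The estimated change is an 11-fold lower number from compound 2 to compound 3 (1.06 log units; beyond the scatter). For compound 3, the expected value is 500 nM, within an estimated range of 30 nM to 8000 nM.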

Compound 3, half-maximal inhibitory concentration: 233 nM
The estimate for compound 3 lay 2.1-fold (0.33 log units) above the measured number, within the range that was stated.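

Placing 1-methyl-1H-indazol-6-yl instead of 3-methylphenyl on this aromatic carbon gives a 25-fold lower number from compound 2 to compound 3 (1.39 log units; beyond the scatter), so this position can shift the number well beyond the scatter, which the swap of small groups on the phenyl ring did not show. Against 3-cyanophenyl the change gives an at least 42-fold lower number from compound 1 to compound 3 (1.63 log units; beyond the scatter), a floor and not an exact size. Compound 1 has a limit of the assay and not a number: the limit of > 10000 nM in this assay, at which 1 of the 3 values shown sits.

On these data alone, whether the gain comes from the added ring, its two nitrogens or its methyl group stays open. Also open, as far as these compounds go, is what an amine or a carboxylic acid on the phenyl ring would do.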